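Swapping fluoro for bromo without a measured starting point

A few compounds are considered here, and "the series" means these few. Any claim that something is new, unique, unknown or untested is made for them only; others in the source may bear on it.

Compound 1 `O=C(CCC1=CCCN(Cc2ccc(F)cc2)C1=O)NO`: "not determined" (no result reported)
Compound 2 `O=C(CCC1=CCCN(CCCc2ccc(-c3ccccc3)cc2)C1=O)NO`: 2490 nM

In a functional assay on ACHN cells (Homo sapiens) for inhibition, read by sulforhodamine B assay (a lower number here means a stronger inhibitor of growth, a higher number a weaker inhibitor of growth), compound 1 has no single number to stand on, as its entry reads "not determined" (no result reported). Compound 3 `O=C(CCC1=CCCN(Cc2ccc(Br)cc2)C1=O)NO` keeps the core of compound 1 and makes one small change, 4-fluorophenyl to 4-bromophenyl: bromo in place of fluoro on an aromatic carbon. Within the data shown here, with no measured step to compare, and no value for compound 1, the size of this change cannot be read from the data. One atom replaced by one atom, with no ring or charge involved, leads to an expectation of no step beyond the scatter in this assay, in either direction. Among the measured compounds shown here, the only number to lean on is that of compound 2 at 2490 nM, so the range must stay wide. For compound 3 the estimated value is 4000 nM, with an expected range from 1000 nM to 16000 nM.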

Compound 3, concentration for 50% growth inhibition: 2480 nM
For compound 3 the middle estimate is 1.6-fold (0.21 log units) above the measured one; low and high end bracket the measured number.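

In this assay, among these compounds, compound 3 gives 2480 nM but compound 1 has no single number, and no step between them can be read. What bromo in place of fluoro does to growth inhibition stays open, and no other finding shown bears on this result.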